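This account rests on a few compounds, and the source may have more. Where it says the series, first, only, none or still open, it means among the compounds named here.

Of the compounds shown here, three built on the shared core have been tested in a functional assay on A549 cells (Homo sapiens) for antiproliferative activity, read by MTT assay, with a stated time of 48 h (on this read-out higher numbers stand for weaker inhibition and lower numbers for stronger inhibition), and a fourth awaits measurement. Compound 1 `Cn1cc(C2=C(c3n[nH]c4ncccc34)C(=O)N(c3cccc4ccccc34)C2=O)c2ccccc21` carries a naphthyl group on its imide nitrogen and an unsubstituted ring nitrogen. In this assay compound 1 returns only a limit, > 100000 nM. Compound 3 `Cn1cc(C2=C(c3nn(CCCO)c4ncccc34)C(=O)NC2=O)c2ccccc21` carries a hydroxypropyl chain and a free imide nitrogen. In this assay compound 3 likewise returns only a limit, > 100000 nM. Among the measured compounds shown here, compound 2 `Cn1cc(C2=C(c3nn(CCCn4ccnc4)c4ncccc34)C(=O)N(c3ccccc3)C2=O)c2ccccc21` is the single member with an actual number: in this assay compound 2 gives 1560 nM. Compound 2 therefore stands alone as the one measured point in the set, with both of its companions sitting at the limit of > 100000 nM in this assay, at which 2 of the 3 values shown sit.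

For the measured compounds named here, no pair of measured compounds differs in only one place, so the data contain no measured step whose size could guide the next one.

Compound 4 `Cn1cc(C2=C(c3nn(CCCN4CCCCC4)c4ncccc34)C(=O)N(c3ccccc3)C2=O)c2ccccc21` differs from compound 2 by piperidin-1-yl in place of 1H-imidazol-1-yl on a saturated chain carbon, three bonds along the chain from an aromatic nitrogen. Going by the values given here, with no measured step of this kind to lean on, compound 4 is expected to land within the usual scatter of compound 2, in no particular direction. Compound 4 is estimated to give 1200 nM, with a plausible range from 400 nM to 4000 nM. This expectation corresponds to a step of a 1.3-fold lower number from compound 2 to compound 4 (0.11 log units; within the scatter), which is expected to stay within the scatter.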

Compound 4, half-maximal inhibitory concentration: 20600 nM
Estimate against measurement, compound 4: 17-fold (1.23 log units) below; measured number above the stated range.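

In this assay, among the compounds shown here, the change from 3-(1H-imidazol-1-yl)propyl to 3-(piperidin-1-yl)propyl gives the first measured step in this set (a 13-fold higher number from compound 2 to compound 4 (1.12 log units; beyond the scatter)), a large one that goes towards weaker inhibition. It shows that the group at the end of this chain is not interchangeable, since a six-membered non-aromatic ring with 1 hetero atom here gives a clearly weaker result than the five-membered aromatic ring with 2 hetero atoms that it replaces. Compound 4 still returns an actual number and so stays apart from the compounds held at the limit, which is a limit and not a number (the relevant line reads: the limit of > 100000 nM in this assay, at which 2 of the 4 values shown sit).

This single step cannot say whether the loss follows from giving up the aromatic ring, from the ring size or from the number of ring nitrogens, and a 1H-pyrazol-1-yl, a morpholin-4-yl or a dimethylamino group at the end of the same chain would help to separate these. It also leaves open whether the same change gives a step of similar size with a shorter or longer chain, or with a group other than phenyl on the imide nitrogen.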